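The source may report more compounds than this note shows. Statements on the series, on what has been measured and on what is new or still open speak of the compounds shown alone.

In an ADME assay on MT4 cells (Homo sapiens) for cytotoxicity, read by MTT assay (a lower number here means that less compound is tolerated, a higher number that more compound is tolerated), compound 1 `Cc1cc(C)cc(S(=O)(=O)c2c(C(=O)NCc3cccc(N)c3)[nH]c3ccc(Cl)cc23)c1` reaches only a limit, > 53400 nM. Compound 2 `Cc1cc(C)cc(S(=O)(=O)c2c(C(=O)NCC(=O)NCc3ccncn3)[nH]c3ccc(Cl)cc23)c1` also reaches only a limit, > 48800 nM. Going by the values given here, compound 3 `Cc1cc(C)cc(S(=O)(=O)c2c(C(=O)NC(C)C(=O)NCc3ccncn3)[nH]c3ccc(Cl)cc23)c1` gives 28100 nM, the only actual number among the three. The next change leads to compound 4 `Cc1cc(C)cc(S(=O)(=O)c2c(C(=O)NCc3ccc4nc(N)[nH]c4c3)[nH]c3ccc(Cl)cc23)c1`: a group of 11 heavy atoms (8 carbon, 3 nitrogen; one five-membered aromatic ring with 2 hetero atoms, one six-membered aromatic ring of carbon only) in place of a group of 12 heavy atoms (8 carbon, 3 nitrogen, 1 oxygen; one six-membered aromatic ring with 2 hetero atoms), on an amide-type nitrogen. Among the compounds with values here, its place is the amide-type nitrogen, where the earlier compounds also differ. The nearest measured precedent is an at least 1.9-fold lower number from compound 1 to compound 3 (0.27 log units; that floor lies within the scatter), since it also exchanges the whole group on that nitrogen. The entering group of compound 4 shares a six-membered aromatic ring of carbon only with the group in compound 1, so this precedent points weakly upward when read in reverse. The methyl step, an at least 1.7-fold lower number from compound 2 to compound 3 (0.23 log units; that floor lies within the scatter), adds little, and a step that the two limits leave unreadable from compound 1 to compound 2 gives no size. In this assay, no change beyond the scatter is therefore expected, and the expected move is a 1.1-fold higher number from compound 3 to compound 4 (0.03 log units; within the scatter). Compound 4 is estimated at 30000 nM, with an expected range of 10000 nM to 70000 nM.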

Compound 4, half-maximal cytotoxic concentration: 5890 nM
Estimate against measurement, compound 4: 5.1-fold (0.71 log units) above, outside the stated range (below it).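

In this assay, going by these compounds alone, the group on the amide-type nitrogen now moves the number beyond the scatter: 2-amino-1H-benzimidazol-6-yl gives a 4.8-fold lower number from compound 3 to compound 4 (0.68 log units; beyond the scatter), whereas the earlier steps at this nitrogen stayed within the scatter at their floors or could not be read. Set against the 3-aminophenyl and ((pyrimidin-4-yl)methyl)carbamoyl groups, the same entering group gives an at least 9.0-fold lower number from compound 1 to compound 4 (0.95 log units; beyond the scatter) and an at least 8.2-fold lower number from compound 2 to compound 4 (0.91 log units; beyond the scatter). Both of these steps are floors: compound 1 and compound 2 each reach only a limit.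

The compounds shown leave open whether the step follows the amino group of 2-amino-1H-benzimidazol-6-yl or the five-membered aromatic ring that carries it. A plain 1H-benzimidazol-6-yl group without the amine, or one with a carboxylic acid in its stead, would separate these two readings.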